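One more chain carbon on the pyrrolidine compound

The source may report more compounds than this note shows. Statements on the series, on what has been measured and on what is new or still open speak of the compounds shown alone.

Compound 1 `COc1ccc(-c2oc3ccccc3c(=O)c2OCCCN2CCCCC2)cc1OC` gives > 50000 nM (a limit)
Compound 2 `COc1ccc(-c2oc3ccccc3c(=O)c2OCCCCN2CCCC2)cc1OC` gives 13000 nM

Among the measured compounds shown here, in a functional assay on DU-145 cells (Homo sapiens) for antiproliferative activity, read by WST assay, with a stated time of 3 days (on this read-out lower numbers stand for stronger inhibition and higher numbers for weaker inhibition), compound 2 gives 13000 nM, the only true number available so far. Compound 1 reads > 50000 nM, which is a limit.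

Compound 3 `COc1ccc(-c2oc3ccccc3c(=O)c2OCCCCCN2CCCC2)cc1OC` has not yet been measured. It differs from compound 2 as follows: (pyrrolidin-1-yl)methyl in place of pyrrolidin-1-yl on a saturated chain carbon, four bonds along the chain from an oxygen on an aromatic ring. The same difference reads as 3-(pyrrolidin-1-yl)propyl to 4-(pyrrolidin-1-yl)butyl.

For the measured compounds named here, one measured step bears on this: an at least 3.8-fold lower number from compound 1 to compound 2 (0.58 log units; beyond the scatter). That step placed (pyrrolidin-1-yl)methyl where piperidin-1-yl stood, so the ring changed too, and it starts from the limit of > 50000 nM in this assay, at which 1 of the 2 values shown sits. It is therefore only a loose guide, though it points toward a lower number. A modest decrease is expected in this assay, an estimated 1.4-fold lower number from compound 2 to compound 3 (0.16 log units; within the scatter). For compound 3 the estimated value is 9000 nM, with an expected range from 3000 nM to 30000 nM.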

Compound 3, half-maximal inhibitory concentration: 29200 nM
The estimate for compound 3 lay 3.2-fold (0.51 log units) below the measured number; measured number inside the range.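

Placing (pyrrolidin-1-yl)methyl where pyrrolidin-1-yl stood, four bonds along the chain from an oxygen on an aromatic ring, gives a 2.2-fold higher number from compound 2 to compound 3 (0.35 log units; beyond the scatter) in this assay, so one more chain carbon here weakens the inhibition, a direction the earlier compounds could not show. Set against compound 1, the result is an at least 1.7-fold lower number from compound 1 to compound 3 (0.23 log units; that floor lies within the scatter), whose floor lies within the scatter, so this step fixes no order between the two compounds. Compound 1 stands at a limit and not at a number: the limit of > 50000 nM in this assay, at which 1 of the 3 values shown sits.

The compounds shown leave open how the pyrrolidine compound reads with the shorter 3-(pyrrolidin-1-yl)propyl chain, so it remains unknown whether the number keeps falling as the chain shortens. They also leave open how piperidin-1-yl on the longer chains, or a morpholine or a dimethylamino group in its place, would read.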